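Swapping the amine on the side chain of a flavone

The source may report more compounds than this note shows. Statements on the series, on what has been measured and on what is new or still open speak of the compounds shown alone.

Measured compounds:
- compound 1, `O=c1cc(-c2ccccc2)oc2cc(O)c(OCCCCN3CCCC3)c(O)c12`: 51000 nM
- compound 2, `CN1CCN(CCCCOc2c(OCc3ccccc3)cc3oc(-c4ccccc4)cc(=O)c3c2O)CC1`: 4400 nM
- compound 3, `COc1cc2oc(-c3ccccc3)cc(=O)c2c(O)c1OCCCCN1CCCC1`: 13000 nM

All three share one core and were tested in a functional assay on A549 cells (Homo sapiens) for antiproliferative activity, read by MTT assay, with a stated time of 48 h; a lower number here means a stronger inhibitor, a higher number a weaker inhibitor. Compound 3 stands second highest of the three numbers: compound 2 sits closest, and compound 1 furthest. Among the compounds with values here, the one step between compounds that differ in a single place is a 3.9-fold lower number from compound 1 to compound 3 (0.59 log units; beyond the scatter), a modest shift.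

Compound 4, `COc1cc2oc(-c3ccccc3)cc(=O)c2c(O)c1OCCCCN1CCN(C)CC1`, is not yet measured. It differs from compound 3 in one place: 4-methylpiperazin-1-yl in place of pyrrolidin-1-yl on a saturated chain carbon, four bonds along the chain from an oxygen on an aromatic ring. Within the data shown here, no measured step bears directly on this change. Compound 2 also carries a 4-methylpiperazin-1-yl group, but it differs from compound 3 in a second place as well, so its values can only be compared, not read as a step: compound 2 gives 4400 nM and compound 3 gives 13000 nM.

Among the measured compounds shown here, with no direct step to lean on, compound 4 is expected to land near compound 3, with at most a small shift toward a lower number, a 1.6-fold lower number from compound 3 to compound 4 (0.21 log units; within the scatter), and its estimate is 8000 nM, ranging from 2500 nM to 25000 nM.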

Compound 4, half-maximal inhibitory concentration: 32000 nM
The estimate for compound 4 lay 4.0-fold (0.60 log units) below the measured number; the whole stated range lies below it.
By their numbers in this assay, from the lowest: compound 2; then compound 3; then compounds 4 and 1 (each within the scatter of the next).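

In this assay, the amine at the end of the chain affects the result: a 2.5-fold higher number from compound 3 to compound 4 (0.39 log units; beyond the scatter) when 4-methylpiperazin-1-yl replaces pyrrolidin-1-yl. The 4-methylpiperazin-1-yl group alone therefore does not bring the low number of compound 2, and the change in the other place also counts: a 7.3-fold higher number from compound 2 to compound 4 (0.86 log units; beyond the scatter) when hydrogen replaces phenyl on the saturated chain carbon bound to an oxygen on an aromatic ring. Nothing measured here explains why either change moves the number.

Still open, going by these compounds, is how a morpholine ring or a dimethylamino group would read on this same chain. Also open, on these data alone, is whether pyrrolidin-1-yl would keep its lower number when paired with the phenyl-bearing group of compound 2.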